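Dropping the chloro group from a fused-ring analogue

A few compounds are considered here, and "the series" means these few. Any claim that something is new, unique, unknown or untested is made for them only; others in the source may bear on it.

Measured in a functional assay on the whole organism with Mus musculus as the target, with a stated time of 15 min; on this read-out higher numbers stand for an effect only at larger amounts of compound and lower numbers for an effect already at smaller amounts:
compound 1 `Cc1csc(C2C=CN=CN2)c1C` gives 30 mg/kg; 3 mg/kg; 3 mg/kg (3 entries)
compound 2 `Cc1sc2cc(Cl)ccc2c1C1C=CN=CN1` gives 30 mg/kg
compound 3 `CCc1ccc(C2C=CN=CN2)s1` gives 10 mg/kg

Among the compounds with a single number in this assay, compound 2 stands at the highest value, meaning it needs the largest dose before an effect is seen. Its nearest neighbour is compound 3, whose lower value lies beyond the usual scatter of repeated measurements, so the gap between compound 2 and compound 3 is a real one. Compound 1 cannot be placed on the same footing, since the several entries of compound 1 in this assay, 30 mg/kg; 3 mg/kg; 3 mg/kg (3 entries) spread widely and do not settle on one number.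

Compound 4 `Cc1sc2ccccc2c1C1C=CN=CN1` is the next compound to be tested. Compared with compound 2, the change is hydrogen in place of chloro on an aromatic carbon. Going by the values given here, no measured pair here shows what such a change does, so no step beyond the scatter is expected in either direction: the step from compound 2 to compound 4 is estimated as no change at the digits printed from compound 2 to compound 4 (within the scatter). Compound 4 is therefore expected to give about 30 mg/kg, with a range from 10 mg/kg to 100 mg/kg.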

Compound 4, minimum effective dose: 3 mg/kg
Estimate against measurement, compound 4: 10-fold (1.00 log units) above; the whole stated range lies above it.
By their numbers in this assay, from the lowest: compound 4; then compound 3; then compound 2.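

Hydrogen in place of chloro on an aromatic carbon of the six-membered ring gives a 10-fold lower number from compound 2 to compound 4 (1.00 log units; beyond the scatter) in this assay. Going by these compounds alone, this is the first pair here that differs in one place only, and it shows that this position is not indifferent: with chloro on this carbon an effect appears only at a larger dose, and with hydrogen it already appears at a smaller one, though the data do not say why. Each of compound 2 and compound 4 rests on a single entry, and repeated entries can spread widely in this assay: the several entries of compound 1 in this assay, 30 mg/kg; 3 mg/kg; 3 mg/kg (3 entries).

Still open, on these data alone, is whether chloro alone has this cost or whether a fluoro, methoxy or amino group on the same carbon would behave alike. As far as these compounds go, it is also open whether such a group would matter on the other carbons of that ring.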